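The compounds below may be only part of what the source reports. "The series", "measured", "known", "first", "only" and "open" are said of these compounds alone.

Of the compounds shown here, two on the shared core have been tested in an assay on isolated protein for inhibition of malate dehydrogenase, mitochondrial (Sus scrofa), with stated times of 45 min and 30 min; on this read-out higher numbers stand for weaker inhibition and lower numbers for stronger inhibition. Compound 1 `O=S(=O)(Nc1ccc(-c2nc3ccccc3o2)cc1)c1ccc(F)c(C(F)(F)F)c1` carries fluoro and trifluoromethyl; in this assay compound 1 returns only a limit, > 63000 nM. Compound 2 `O=S(=O)(Nc1ccc(-c2nc3ccccc3o2)cc1)c1cccc(Cl)c1` carries chloro; in this assay compound 2 likewise returns only a limit, > 63000 nM. On the numbers shown, compound 2 thus stands only at a limit, and the one further value shown is a limit of the same kind (the limit of > 63000 nM in this assay, at which 2 of the 2 values shown sit). Within the data shown here, no step between measured compounds is computed; neither gives a number.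

Compound 3 `O=S(=O)(Nc1ccc(-c2nc3ccccc3o2)cc1)c1cccc(C(F)(F)F)c1` has not been measured in this assay. It differs from compound 2 by trifluoromethyl in place of chloro on an aromatic carbon; in words, trifluoromethyl in place of chloro on an aromatic carbon. With both measured compounds at the limit, no step beyond the usual scatter is expected in this assay, and the expected step from compound 2 to compound 3 is a step that the limit leaves unreadable from compound 2 to compound 3. Compound 3 is estimated at 100000 nM, within 30000 nM to 300000 nM, with a high chance that this assay again reports only a limit.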

Compound 3, half-maximal inhibitory concentration: > 63000 nM
Compound 3 gave a limit, no number; the forecaster's own chance of this, stated with the estimate: 85%; the middle value is on the limit's open side.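

In this assay, compound 3 returns only a limit, as do compound 1 and compound 2, so no step from compound 1 or compound 2 to compound 3 can be read: the limit of > 63000 nM in this assay, at which 3 of the 3 values shown sit.

The compounds shown leave open whether any substitution on the shared core gives a measurable value in this assay.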